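Moving the Thiophene Attachment Point in Compound 4

A few compounds are considered here, and "the series" means these few. Any claim that something is new, unique, unknown or untested is made for them only; others in the source may bear on it.

Measured so far:
Compound 1, `C=C(Br)C(=O)Nc1ccc2c(c1)/C(=C/c1cccs1)C(=O)N2`: 210 nM
Compound 2, `C#CC(=O)Nc1ccc2c(c1)/C(=C/c1ccc[nH]1)C(=O)N2`: 340 nM
Compound 3, `C=C(Br)C(=O)Nc1ccc2c(c1)CC(=O)N2`: 1100 nM

All three were tested in a functional assay on Jurkat cells (Homo sapiens) for antiproliferative activity, read by MTT assay, with a stated time of 72 h; on this read-out lower numbers stand for stronger inhibition and higher numbers for weaker inhibition. In this assay compound 1 gives 210 nM. Compound 2 gives 340 nM, which lies within the usual scatter of the number for compound 1, so the two cannot be told apart. Compound 3, which has no aromatic ring hanging from the shared core, gives 1100 nM, a number beyond the scatter higher than that of compound 1, so compound 3 is the weaker inhibitor of that pair. For the measured compounds named here, no pair among the measured compounds differs in only one place, so no measured step is available to guide the next change.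

Compound 4, `C=C(Br)C(=O)Nc1ccc2c(c1)/C(=C/c1ccsc1)C(=O)N2`, has not yet been measured. It differs from compound 1 in one place: thiophen-3-yl in place of thiophen-2-yl on a double-bonded chain carbon bound to a double-bonded ring carbon. The thiophene ring stays, only its point of attachment moves. With nothing in the measured set that tracks such a shift, the expectation is a step from compound 1 to compound 4 in this assay that stays within the scatter, with at most a slight drift toward weaker inhibition. Compound 4 is therefore expected to give about 280 nM, estimated to fall between 120 nM and 700 nM. This expectation means a step of a 1.3-fold higher number from compound 1 to compound 4 (0.12 log units; within the scatter).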

Compound 4, half-maximal inhibitory concentration: 190 nM
Beside the measured number, compound 4's estimate is 1.5-fold (0.17 log units) above it; low and high end bracket the measured number.
By their numbers in this assay, from the lowest: compounds 4, 1 and 2 (each within the scatter of the next); then compound 3.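

In this assay, putting thiophen-3-yl in place of thiophen-2-yl on a double-bonded chain carbon bound to a double-bonded ring carbon gives a 1.1-fold lower number from compound 1 to compound 4 (0.04 log units; within the scatter). For the compounds shown here, this is the first measured step at this place, and it shows that the assay cannot tell the two attachment points of the thiophene apart: the ring can be joined through either carbon without a readable difference in antiproliferative activity. Nothing available accounts for why the two compounds read alike, so the result stands as an observation without an explanation.

On these data alone, the step covers only a shift within one ring, so it remains open how this place would respond to a different ring, such as phenyl or furan, or to a thiophene carrying an amine or a carboxylic acid. The amide chain bearing the bromine is the same in compound 1 and compound 4, so this step also says nothing about how much that part of the molecule contributes to the activity.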